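The source may hold more compounds than are shown below. What is called first, only, known or untested is meant among the compounds shown, and "the series" means these compounds.

In a functional assay on RPMI-8226 cells (Homo sapiens) for cytotoxicity, read by sulforhodamine B assay, with a stated time of 48 h (on this read-out lower numbers stand for stronger inhibition of growth and higher numbers for weaker inhibition of growth), compound 2 `ClCc1ccccc1Cn1cnc2c(Cl)nc(Cl)nc21` gives 1540 nM, the lowest of the two numbers measured. Compound 3 `Nc1nc(Cl)c2ncn(Cc3cccc(CCl)c3)c2n1` gives 11800 nM. Compound 1 `Nc1nc(Cl)c2ncn(Cc3ccccc3CCl)c2n1` gives > 100000 nM, which is the limit of > 100000 nM in this assay, at which 1 of the 3 values shown sits, and not a measured number. Within the data shown here, the one measured step at the same aromatic carbon is an at least 64-fold lower number from compound 1 to compound 2 (1.81 log units; beyond the scatter), where chloro took the place of amino; it shows that this carbon is sensitive to what it carries. Compound 4 `ClCc1ccccc1Cn1cnc2c(Cl)ncnc21` differs from compound 2 by hydrogen in place of chloro on an aromatic carbon. Among the measured compounds shown here, no measured step shows chloro giving way to hydrogen, so the expected step is modest, a rise in the number of a 2.3-fold higher number from compound 2 to compound 4 (0.36 log units; beyond the scatter). Compound 4 is therefore estimated at 3500 nM, within a range from 1000 nM to 12000 nM.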

Compound 4, concentration for total growth inhibition: 40700 nM
Compound 4: middle estimate off by 12-fold (1.07 log units), on the low side; the whole stated range lies below it.
By their numbers in this assay, from the lowest: compound 2; then compound 3; then compound 4. At a limit, above all of these: compound 1.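

The chloro group on the aromatic carbon between two ring nitrogen atoms matters a great deal: with hydrogen in its place there is a 26-fold higher number from compound 2 to compound 4 (1.42 log units; beyond the scatter). Hydrogen at this carbon also compares with amino, giving an at least 2.4-fold lower number from compound 1 to compound 4 (0.39 log units; beyond the scatter), so the three groups seen here rank chloro, then hydrogen, then amino, from the lowest number to the highest. The value of compound 1 is a limit and not a number: the limit of > 100000 nM in this assay, at which 1 of the 4 values shown sits.

Going by these compounds, whether another group on this carbon, such as bromo or methoxy, would match chloro remains open.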